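A few compounds are considered here, and "the series" means these few. Any claim that something is new, unique, unknown or untested is made for them only; others in the source may bear on it.

Compound 1 `O=C(CCCCCCNC(=O)C(O)(O)C(F)(F)F)Nc1ncc(-c2ccc(Br)cc2)s1` gives 2460 nM
Compound 2 `CCOc1ccc(-c2cnc(NC(=O)CCCCCCNC(=O)C(O)(O)C(F)(F)F)s2)cc1` gives 4050 nM

Both numbers come from a functional assay on HCT-116 cells (Homo sapiens) for inhibition, read by colorimetric assay, with a stated time of 3 days (a lower number here means a stronger inhibitor, a higher number a weaker inhibitor), and these two are all that has been measured so far. Compound 2 lies within the scatter of compound 1, so the two cannot be told apart on this evidence.

The next compound is compound 3 `O=C(CCCCCCNC(=O)C(O)(O)C(F)(F)F)Nc1ncc(-c2ccc(O)cc2)s1`, in which the ethoxy group of compound 2 becomes hydroxy: hydrogen in place of ethyl on an oxygen on an aromatic ring. Put simply, this is hydrogen in place of ethyl on an oxygen on an aromatic ring.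

Among the measured compounds shown here, only one measured step bears on this change: a 1.6-fold higher number from compound 1 to compound 2 (0.22 log units; within the scatter). That step put ethoxy in place of bromo on an aromatic carbon, so it altered the same group that changes now, and it stayed within the scatter. For the measured compounds named here, no compound with a hydroxy group has been measured, which makes this a thin guide. No step beyond the scatter is therefore expected in this assay, in either direction. The expected change is small: a 1.4-fold lower number from compound 2 to compound 3 (0.13 log units; within the scatter). For compound 3 the estimated value is 3000 nM, with an expected range from 1100 nM to 8000 nM.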

Compound 3, half-maximal inhibitory concentration: 1020 nM
The estimate for compound 3 lay 2.9-fold (0.47 log units) above the measured number, and the stated range ends above it.
By their numbers in this assay, from the lowest: compound 3; then compounds 1 and 2 (each within the scatter of the next).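

In this assay, going from 4-ethoxyphenyl to 4-hydroxyphenyl gives a 4.0-fold lower number from compound 2 to compound 3 (0.60 log units; beyond the scatter), and hydroxy in place of bromo gives a 2.4-fold lower number from compound 1 to compound 3 (0.38 log units; beyond the scatter). Bromo and ethoxy could not be told apart at this place on the ring, so these two modest steps are the first sign that the group there can change the number beyond ordinary scatter, with hydroxy separated from both earlier groups. No measurement shown here explains why the number falls with hydroxy, so the reason remains unknown.

The compounds shown compare only three groups at this place, all on the same core and chain, so it remains open whether an amine, a methoxy group or a carboxylic acid there would fall with hydroxy or with bromo and ethoxy. Going by these compounds, it is also open whether the hydroxy step would keep its size with a shorter or longer chain, or with another group in place of the trifluoromethyl end.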